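The source may hold more compounds than are shown below. What is called first, only, known or untested is meant among the compounds shown, and "the series" means these compounds.

Compound 1 `CC(=O)N1CCN(c2ccc(Nc3ncc(C(F)(F)F)c(N4Cc5cccc(N(C)S(C)(=O)=O)c5C4)n3)cc2)CC1` gives 970 nM in a functional assay on OVCAR-3 cells (Homo sapiens) for antiproliferative activity, read by spectrophotometry, with a stated time of 2 days (on this read-out higher numbers stand for weaker inhibition of growth and lower numbers for stronger inhibition of growth), and compound 2 `COc1cc(N2CCN(C(C)=O)CC2)ccc1Nc1ncc(C(F)(F)F)c(N2Cc3cccc(N(C)S(C)(=O)=O)c3C2)n1` gives 1600 nM. Going by the values given here, the only single-point step among the measured compounds is a 1.6-fold higher number from compound 1 to compound 2 (0.22 log units; within the scatter). Compound 3 `CN(c1cccc2c1CN(c1nc(Nc3cccc(Oc4ccccc4)c3)ncc1C(F)(F)F)C2)S(C)(=O)=O` gives 24900 nM and stands highest of the three numbers, beyond the scatter from both compound 2 and compound 1; it is thus the weakest inhibitor of growth among the measured set.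

Compound 4 `CN(c1cccc2c1CN(c1nc(Nc3cccc(C(F)(F)F)c3)ncc1C(F)(F)F)C2)S(C)(=O)=O` has not yet been measured. It differs from compound 3 by trifluoromethyl in place of phenoxy on an aromatic carbon, the trifluoromethyl sitting on an aromatic carbon meta to a large group.

Among the compounds with values here, no measured step bears on this change: the one step in hand, from compound 1 to compound 2, concerns a methoxy in place of hydrogen on a different part of the series and lies within the scatter, so it gives no direction for an exchange of phenoxy for trifluoromethyl. Compound 3 is the only anchor. With nothing to support a shift, the expectation for compound 4 is a step of a 1.7-fold lower number from compound 3 to compound 4 (0.22 log units; within the scatter), essentially none beyond the scatter, the wide range reflecting the missing precedent. Compound 4 is therefore estimated at 15000 nM, between 4000 nM and 60000 nM.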

Compound 4, concentration for 50% growth inhibition: > 30000 nM
Compound 4 ended at the assay's limit (the forecaster's own chance of this, stated with the estimate: 10%); middle value at least 2.0-fold (0.30 log units) away from the limit.
By their numbers in this assay, from the lowest: compounds 1 and 2 (each within the scatter of the next); then compound 3. At a limit, above all of these: compound 4.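

In this assay compound 4 gives > 30000 nM, which is a limit and not a number: the limit of > 30000 nM in this assay, at which 1 of the 4 values shown sits.

As far as these compounds go, the exchange at this aromatic carbon, meta to a large group, reads as an at least 1.2-fold higher number from compound 3 to compound 4 (0.08 log units; that floor lies within the scatter), so only a floor is known, and the true size of the step remains unknown. Going by these compounds alone, this is the first reading of any change at this position, and it shows that trifluoromethyl, with no ring and no hydrogen-bond acceptor, gives no gain in growth inhibition over phenoxy, which the within-scatter methoxy step elsewhere could not show.

From the compounds shown here alone, whether an amine or a carboxylic acid on this aromatic carbon would bring the number down remains open. Also open, going by these compounds, is how the phenoxy to trifluoromethyl exchange would read on a compound whose value stands clear of the limit.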